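Side-chain variation and tolerated concentration in one series

The source may report more compounds than this note shows. Statements on the series, on what has been measured and on what is new or still open speak of the compounds shown alone.

For the measured compounds named here, in an ADME assay on MT4 cells (Homo sapiens) for cytotoxicity, read by MTT assay, with a stated time of 5 days (a lower number here means that less compound is tolerated, a higher number that more compound is tolerated), compound 1 `CCCN(c1ccnc(Nc2ccc(C#N)cc2)n1)c1c(F)cc(-c2ccc(C#N)cc2)cc1F` gives 212000 nM, the second highest of the three numbers measured so far. Compound 2 `CC(C)N(c1ccnc(Nc2ccc(C#N)cc2)n1)c1c(F)cc(-c2ccc(C#N)cc2)cc1F` gives 172000 nM and compound 3 `CC(C)CN(c1ccnc(Nc2ccc(C#N)cc2)n1)c1c(F)cc(-c2ccc(C#N)cc2)cc1F` gives 241000 nM; the steps of a 1.2-fold lower number from compound 1 to compound 2 (0.09 log units; within the scatter), a 1.1-fold higher number from compound 1 to compound 3 (0.06 log units; within the scatter) and a 1.4-fold higher number from compound 2 to compound 3 (0.15 log units; within the scatter) all sit within the scatter. Compound 4 `N#Cc1ccc(Nc2nccc(N(CC(O)CO)c3c(F)cc(-c4ccc(C#N)cc4)cc3F)n2)cc1` differs from compound 1 by 1,2-dihydroxyethyl in place of ethyl on a saturated chain carbon bound to a nitrogen on an aromatic ring. Going by the values given here, none of the measured steps brings hydroxyl groups onto the chain, so they bear on this change only by showing that reshaping the chain has so far not moved the number beyond the scatter. The step of a 1.2-fold higher number from compound 1 to compound 4 (0.07 log units; within the scatter) is therefore expected to be small. Compound 4 is estimated at 250000 nM, with a range of 120000 nM to 520000 nM.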

Compound 4, half-maximal cytotoxic concentration: 19500 nM
Estimate against measurement, compound 4: 13-fold (1.11 log units) above, and the stated range ends above it.
By their numbers in this assay, from the lowest: compound 4; then compounds 2, 1 and 3 (each within the scatter of the next).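

In this assay the chain on the nitrogen on an aromatic ring is not as indifferent as the alkyl compounds suggested: 2,3-dihydroxypropyl in compound 4 gives an 11-fold lower number from compound 1 to compound 4 (1.04 log units; beyond the scatter) and a 12-fold lower number from compound 3 to compound 4 (1.09 log units; beyond the scatter) and an 8.8-fold lower number from compound 2 to compound 4 (0.95 log units; beyond the scatter). Reshaping the alkyl chain stays within the scatter, whereas this change lies beyond it against each alkyl compound. No measurement shown here accounts for the lower number. On these data alone, whether a chain with a single hydroxyl group would give the same lower number stays open. So does the outcome for an amine or a carboxylic acid at this place.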